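Triazolyl to thiazolyl on the amino nitrogen: a limited series

This account rests on a few compounds, and the source may have more. Where it says the series, first, only, none or still open, it means among the compounds named here.

The three measured compounds share one core, seen in compound 1 `Nc1nc2ccccc2c(=O)o1`, compound 2 `CNc1nc2ccccc2c(=O)o1` and compound 3 `O=c1oc(Nc2nc[nH]n2)nc2ccccc12`. In an assay on isolated protein for inhibition of complement C1r subcomponent (Homo sapiens) (on this read-out lower numbers stand for stronger inhibition and higher numbers for weaker inhibition), compound 1 gives > 62500 nM, a limit of the assay rather than a number. In this assay compound 2 likewise gives only a limit, > 62500 nM. Compound 3 also stands at a limit in this assay, > 62500 nM, so it cannot be placed against the other two. The steps a step that the two limits leave unreadable from compound 1 to compound 2, a step that the two limits leave unreadable from compound 1 to compound 3 and a step that the two limits leave unreadable from compound 2 to compound 3 therefore remain unreadable, because of the limit of > 62500 nM in this assay, at which 3 of the 3 values shown sit.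

Compound 4 `O=c1oc(Nc2nccs2)nc2ccccc12` has not yet been measured. It differs from compound 3 in one place: 1,3-thiazol-2-yl in place of 1H-1,2,4-triazol-3-yl on a nitrogen on an aromatic ring. Among the measured compounds shown here, no measured step bears on this change, and all three values so far are limits. The expected step that the limit leaves unreadable from compound 3 to compound 4 is therefore no more than a guess that compound 4 stays near the limit. Compound 4 is estimated at 100000 nM in this assay, between 20000 nM and 500000 nM.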

Compound 4, half-maximal inhibitory concentration: > 62500 nM
Compound 4 gave a limit, no number; the forecaster's own chance of this, stated with the estimate: 80%; the middle value lies beyond the limit too.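

Compound 4 also gives only a limit, so its steps from compound 1, compound 2 and compound 3 cannot be read, because no compound here has a numerical value: the limit of > 62500 nM in this assay, at which 4 of the 4 values shown sit.

The compounds shown leave open whether any group on this nitrogen gives measurable inhibition in this assay.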